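The compounds below may be only part of what the source reports. "The series", "measured", "known", "first", "only" and "open" are said of these compounds alone.

Measured so far in a functional assay on DU-145 cells (Homo sapiens) for inhibition, read by trypan blue exclusion, with a stated time of 96 h; on this read-out lower numbers stand for stronger inhibition of growth and higher numbers for weaker inhibition of growth:
- compound 1 `Cc1ccc(S(=O)(=O)/C(=C/c2sccc2C)C(=O)c2ccc(Cl)cc2)cc1` gives 10000 nM
- compound 2 `COc1ccccc1/C=C(\C(=O)c1ccc(Cl)cc1)S(=O)(=O)c1ccc(C)cc1` gives 1000 nM
- compound 3 `Cc1ccc(S(=O)(=O)/C(=C/c2ccc(N(C)C)cc2)C(=O)c2ccc(Cl)cc2)cc1` gives > 100000 nM (a limit of the assay, not a number)

Compound 3 stands at the limit of > 100000 nM in this assay, at which 1 of the 3 values shown sits. Its steps from both other compounds lie beyond the scatter, and it sits at the weak end of the three.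

Next in the series is compound 4 `CC(=O)Oc1ccc(/C=C(\C(=O)c2ccc(Cl)cc2)S(=O)(=O)c2ccc(C)cc2)cc1`. Relative to compound 3, it has acetoxy in place of dimethylamino on an aromatic carbon, para to a large group: acetoxy in place of dimethylamino on an aromatic carbon.

Two measured steps bring in the 4-(dimethylamino)phenyl group that this change removes. One is an at least 10-fold higher number from compound 1 to compound 3 (1.00 log units; beyond the scatter) and the other, the large one, is an at least 100-fold higher number from compound 2 to compound 3 (2.00 log units; beyond the scatter). The step of a 10-fold lower number from compound 1 to compound 2 (1.00 log units; beyond the scatter) shows that the aryl group at this place also moves the number when no dimethylamino group is involved. Among the measured compounds shown here, no measured compound carries acetoxy, so these steps give a direction more firmly than a size.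

In this assay, a clear fall in the number is expected, of a size comparable to those two steps. The expected change is an at least 20-fold lower number from compound 3 to compound 4 (1.30 log units; beyond the scatter). The estimate for compound 4 is 5000 nM, with an expected range from 500 nM to 50000 nM.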

Compound 4, concentration for 50% growth inhibition: 25000 nM
Compound 4: the middle estimate sits 5.0-fold (0.70 log units) below what was measured; the measured number falls inside the stated range.
By their numbers in this assay, from the lowest: compound 2; then compound 1; then compound 4. At a limit, above all of these: compound 3.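

In this assay, the place para to a large group responds to a change of substituent, with acetoxy in place of dimethylamino giving an at least 4.0-fold lower number from compound 3 to compound 4 (0.60 log units; beyond the scatter). Going by these compounds, the size of this step remains open-ended, as compound 3 is held at a limit of the assay and not at a number: the limit of > 100000 nM in this assay, at which 1 of the 4 values shown sits. Replacing dimethylamino does not bring this aryl group level with the other two, as shown by a 25-fold higher number from compound 2 to compound 4 (1.40 log units; beyond the scatter) and by a 2.5-fold higher number from compound 1 to compound 4 (0.40 log units; beyond the scatter). Among the compounds shown, the 4-(dimethylamino)phenyl and 4-acetoxyphenyl groups therefore both sit on the weak side of the 2-methoxyphenyl and 3-methylthiophen-2-yl groups, with no compound going against this.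

The compounds shown do not separate the effect of the substituent from that of its place, as 2-methoxyphenyl and 4-acetoxyphenyl differ in both. A 4-methoxyphenyl or 2-acetoxyphenyl group would address that question, while a 4-hydroxyphenyl group would show how the number responds when the acetyl part of acetoxy is absent.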